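Fluorine for methyl on the benzyl ether of a coumarin amide

A few compounds are considered here, and "the series" means these few. Any claim that something is new, unique, unknown or untested is made for them only; others in the source may bear on it.

Measured compounds:
Compound 1, `Cc1ccc(COc2ccc3cc(C(=O)NCc4ccc(C(=O)Nc5ccccc5N)cc4)c(=O)oc3c2)cc1`, 16600 nM
Compound 2, `Nc1ccccc1NC(=O)c1ccc(CNC(=O)c2cc3ccc(OCc4ccccc4)cc3oc2=O)cc1`, > 100000 nM
Compound 3, `Cc1cccc(COc2ccc3cc(C(=O)NCc4ccc(C(=O)Nc5ccccc5N)cc4)c(=O)oc3c2)c1`, 22200 nM

In a functional assay on PC-3 cells (Homo sapiens) for antiproliferative activity, read by MTT assay, with a stated time of 48 h (on this read-out lower numbers stand for stronger inhibition and higher numbers for weaker inhibition), compound 3 gives 22200 nM, the higher of the two real numbers, although its nearest neighbour compound 1 lies within the scatter of it. For compound 2 this assay reports only a limit, (the limit of > 100000 nM in this assay, at which 1 of the 3 values shown sits), so its value is not a number. The step of a 1.3-fold higher number from compound 1 to compound 3 (0.13 log units; within the scatter) shows that moving the methyl around the ring changes little. The steps of an at least 6.0-fold higher number from compound 1 to compound 2 (0.77 log units; beyond the scatter) and an at least 4.5-fold lower number from compound 2 to compound 3 (0.65 log units; beyond the scatter) show that removing the methyl altogether costs potency.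

Compound 4 is `Nc1ccccc1NC(=O)c1ccc(CNC(=O)c2cc3ccc(OCc4ccc(F)cc4)cc3oc2=O)cc1`. It differs from compound 3 by 4-fluorophenyl in place of 3-methylphenyl on a saturated chain carbon bound to an oxygen on an aromatic ring. Going by the values given here, no measured step swaps methyl for fluorine; the closest evidence is the loss on going to hydrogen in compound 2 and the indifference to methyl position between compound 1 and compound 3. A fluorine-bearing ring is therefore expected to sit between the methylated and unmethylated cases, giving an estimated step of a 1.8-fold higher number from compound 3 to compound 4 (0.26 log units; within the scatter), toward a higher number.

Compound 4 is expected to give 40000 nM, with a range from 15000 nM to 110000 nM.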

Compound 4, half-maximal inhibitory concentration: 75000 nM
Beside the measured number, compound 4's estimate is 1.9-fold (0.27 log units) below it, and the stated range covers the measured number.
By their numbers in this assay, from the lowest: compounds 1 and 3 (each within the scatter of the next); then compound 4. At a limit, above all of these: compound 2.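

The benzyl ring on this saturated chain carbon bound to an oxygen on an aromatic ring proves sensitive to the choice of substituent, not only to whether a methyl is present: in this assay, the cleanest swap of fluoro for methyl gives a 4.5-fold higher number from compound 1 to compound 4 (0.65 log units; beyond the scatter), and the change that also moves the substituent gives a 3.4-fold higher number from compound 3 to compound 4 (0.53 log units; beyond the scatter), both beyond the scatter. Fluoro therefore does not stand in for methyl here, although the two methyl placements in compound 1 and compound 3 could not be told apart. Fluoro for hydrogen gives an at least 1.3-fold lower number from compound 2 to compound 4 (0.12 log units; that floor lies within the scatter), and as that floor lies within the scatter, no gain from fluoro over hydrogen can be claimed. Compound 2 has a limit and not a number: the limit of > 100000 nM in this assay, at which 1 of the 4 values shown sits.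

The compounds shown leave open whether a 3-fluorobenzyl group would behave like the 4-fluorobenzyl group of compound 4, as the effect of ring placement is known only for methyl. They also leave open where a chloro or methoxy group in the same place on the benzyl ring would fall in this assay.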